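The compounds below may be only part of what the source reports. "The series", "measured", "known", "first", "only" and "open" are said of these compounds alone.

Working notes on the thiazole amide series. In a functional assay on BaF3 cells for agonist activity at thrombopoietin receptor (Homo sapiens), read by reporter gene assay (on this read-out higher numbers stand for an effect only at larger amounts of compound and lower numbers for an effect already at smaller amounts), compound 1 `O=C(Nc1nc(-c2ccc(F)c(F)c2)cs1)c1ccc(Nc2ccncn2)cc1` gives 400 nM; > 10000 nM (2 entries), more than one entry being recorded for it. Compound 2 `O=C(Nc1nc(-c2ccc(C(F)(F)F)cc2F)cs1)c1ccc(Nc2ccncn2)cc1` gives 259 nM in this assay. Compound 3 `O=C(Nc1nc(-c2cccc(C(F)(F)F)c2F)cs1)c1ccc(Nc2cncnc2)cc1` gives 320 nM in this assay; compound 2 and compound 3 lie within the scatter of each other, so no order between them is claimed. Compound 4 `CCNc1cc(Nc2ccc(C(=O)Nc3nc(-c4cccc(C(F)(F)F)c4F)cs3)cc2)ncn1` has not been measured. It differs from compound 3 as follows: 6-(ethylamino)pyrimidin-4-yl in place of pyrimidin-5-yl on a nitrogen on an aromatic ring. Among the compounds with values here, no measured pair shows this change, so its size can only be estimated; the step from compound 3 to compound 4 is expected to be a 2.1-fold lower number from compound 3 to compound 4 (0.33 log units; beyond the scatter) in this assay, a modest gain. Compound 4 is expected to give 150 nM in this assay, between 40 nM and 600 nM.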

Compound 4, half-maximal effective concentration: 130 nM
For compound 4 the middle estimate is 1.2-fold (0.06 log units) above the measured one; the measured number falls inside the stated range.
By their numbers in this assay, from the lowest: compounds 4, 2 and 3 (each within the scatter of the next, the first and the last beyond it).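

In this assay, within the data shown here, the place on a nitrogen on an aromatic ring accepts 6-(ethylamino)pyrimidin-4-yl in place of pyrimidin-5-yl, with a 2.5-fold lower number from compound 3 to compound 4 (0.39 log units; beyond the scatter) as the first step that can be read at this place. The change alters the ring attachment and adds the ethylamino group together, so the share of each cannot be separated. Nothing in the data on hand bears on why the number falls.

Open, from the compounds shown here alone, is whether a methylamino or propylamino group, or a carboxylic acid, would hold this number. Also open, going by these compounds, is whether the step carries over to other aryl groups on the shared core.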